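Pyrazoline series: kinase inhibition, hydroxyphenyl to fluorohydroxyphenyl

A few compounds are considered here, and "the series" means these few. Any claim that something is new, unique, unknown or untested is made for them only; others in the source may bear on it.

The series shares one core, varied at a saturated ring carbon. Compound 1 `CC(C)(C)C1=NN(c2ccc(Cl)cc2)C(c2ccc(Cl)cc2)C1` carries a 4-chlorophenyl group there; in an assay on U-937 cells for inhibition of protein kinase C zeta type (Homo sapiens), read by reporter gene assay (a higher number here means a weaker inhibitor, a lower number a stronger inhibitor), compound 1 gives "not determined" (no result reported). Compound 2 `CC(C)(C)C1=NN(c2ccc(Cl)cc2)C(c2ccc(Br)cc2)C1` carries a 4-bromophenyl group there; in this assay compound 2 gives "not determined" (no result reported). Neither of them gives an anchor. Within the data shown here, compound 3 `CC(C)(C)C1=NN(c2ccc(Cl)cc2)C(c2cccc(O)c2)C1` carries a 3-hydroxyphenyl group and is the only entry with a number: in this assay compound 3 gives 2000 nM. Among the measured compounds shown here, with no second number in the set, compound 3 stands alone, neither strongest nor weakest, and no measured step exists to calibrate the next change.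

Compound 4 `CC(C)(C)C1=NN(c2ccc(Cl)cc2)C(c2ccc(O)c(F)c2)C1` differs from compound 3 in one place: 3-fluoro-4-hydroxyphenyl in place of 3-hydroxyphenyl on a saturated ring carbon. The hydroxyl keeps its place on an aromatic carbon ring, with a fluorine added alongside. For the measured compounds named here, nothing in the set shows how such a change moves the read-out, so the expectation rests on the single value of compound 3 and on the usual scatter. The step of a 1.3-fold higher number from compound 3 to compound 4 (0.10 log units; within the scatter) is expected to be small, in no fixed direction, and likely within the scatter of repeated runs. Compound 4 is therefore expected to give about 2500 nM, with a range from 800 nM to 8000 nM, and a real chance that the assay returns only a limit.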

Compound 4, half-maximal inhibitory concentration: 3700 nM
For compound 4 the middle estimate is 1.5-fold (0.17 log units) below the measured one; the range from low to high includes it.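

In this assay the series gains its first measured step at the saturated ring carbon: a 1.9-fold higher number from compound 3 to compound 4 (0.27 log units; within the scatter), for 3-fluoro-4-hydroxyphenyl in place of 3-hydroxyphenyl. This gives the first calibration at this position, showing that this exchange of one hydroxyl-bearing phenyl group for another, with a fluorine added, does not separate the two compounds beyond repeat-measurement scatter, while compound 1 and compound 2 carry no number, so steps involving the 4-chlorophenyl and 4-bromophenyl groups cannot be read. No measurement in hand bears on the reason for this outcome.

The step changes the hydroxyl placement and adds a fluorine at once, so a 4-hydroxyphenyl or 3-fluorophenyl group at this carbon would be needed to read the two changes apart. On these data alone, how an amine, a carboxylic acid or a longer alkyl chain at the same carbon would read in this assay remains open, as does whether any group there can move the value beyond the scatter.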